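Dichlorophenyl variant of the acylated core of compound 2

The compounds below may be only part of what the source reports. "The series", "measured", "known", "first", "only" and "open" are said of these compounds alone.

Two compounds of the series carry a number in a functional assay on PC-3 cells (Homo sapiens) for antiproliferative activity, read by MTT assay, tested at 5 uM (a higher number here means a stronger effect of the compound at the concentration tested, a lower number a weaker effect), so far. Compound 1 `COc1cc(C(=O)N/N=C/c2ccc(F)c(F)c2)cc(OC)c1OC` gives 43.7% in this assay. Compound 2 `COc1cc(C2=NN(C(C)=O)C(c3ccc(F)cc3)O2)cc(OC)c1OC` gives 0.1% in this assay, the lowest of the two numbers, and the gap to compound 1 lies beyond the scatter. Among the measured compounds shown here, no pair of measured compounds differs in only one place, so no measured step is at hand to calibrate the change from compound 2 to compound 3.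

Compound 3 `COc1cc(C2=NN(C(C)=O)C(c3ccc(Cl)c(Cl)c3)O2)cc(OC)c1OC` shares the core of compound 2 and differs from it in one place: 3,4-dichlorophenyl in place of 4-fluorophenyl on a saturated ring carbon. Both groups are single six-membered carbon-only aromatic rings without donors or acceptors, so the change is a swap of halogen pattern on a side ring and nothing more. Starting from compound 2, which gives essentially no effect in this assay, a small rise is expected, but the expected step from compound 2 to compound 3 is a number 7.9 percentage points higher from compound 2 to compound 3 (within the scatter) and is not expected to carry compound 3 into the range of compound 1. Compound 3 is thus estimated at 8% in this assay, with a range from 0% to 28%.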

Compound 3, a percentage reported as inhibition, at one concentration (the size of the read-out at that concentration, not a potency): 26.1%
Beside the measured number, compound 3's estimate is 18.1 percentage points below it; low and high end bracket the measured number.
By their numbers in this assay, from the lowest: compound 2; then compound 3; then compound 1.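

In this assay the saturated ring carbon of the shared core now has its first measured step, with 3,4-dichlorophenyl in place of 4-fluorophenyl giving a number 26 percentage points higher from compound 2 to compound 3 (beyond the scatter). Both groups are single six-membered carbon-only aromatic rings without hydrogen-bond donors or acceptors, so the step comes with a change in the halogen pattern of the side ring alone, and this position on the core of compound 2 is not indifferent to that pattern. No measurement at hand accounts for the step, and the data do not separate the identity of the halogen from the number of halogens or their placement on the ring.

Open, on these data alone, is whether a phenyl ring carrying a single chlorine, a trifluoromethyl group or a methoxy group at this position would give a step of similar size, or whether a dimethylamino group or a carboxylic acid on the ring would keep any of it. Also open, as far as these compounds go, is whether the same gain would hold with a propanoyl group or a longer acyl chain in place of the acetyl group.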